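This account rests on a few compounds, and the source may have more. Where it says the series, first, only, none or still open, it means among the compounds named here.

Measured compounds:
Compound 1 `CCCSc1nc(N)nc2c1ncn2/C=C1/CC1(CO)CO` — in an ADME assay on Akata cells (Homo sapiens) for cytotoxicity, with a stated time of 7 days (on this read-out lower numbers stand for higher toxicity in this test and higher numbers for lower toxicity in this test), compound 1 reaches only the limit > 20000 nM.
Compound 2 `CC(C)Nc1nc(N)nc2c1ncn2/C=C1/CC1(CO)CO` — in this assay compound 2 reaches only the limit > 24000 nM.
Compound 3 `CCCCCCCCSc1nc(N)nc2c1ncn2/C=C1/CC1(CO)CO` — in this assay compound 3 reaches only the limit > 20000 nM.

Compound 3 thus stands at a limit, and the two further values are limits as well. Compound 4 `Nc1nc(SCc2ccccc2)c2ncn(/C=C3/CC3(CO)CO)c2n1` differs from compound 3 by phenyl in place of heptyl on a saturated chain carbon bound to a sulfur. The steps that touch the same sulfur-bearing side chain are a step that the two limits leave unreadable from compound 1 to compound 3 and a step that the two limits leave unreadable from compound 2 to compound 3; both are unreadable because of the limit of > 20000 nM in this assay, at which 2 of the 3 values shown sit, and (the limit of > 24000 nM in this assay, at which 1 of the 3 values shown sits). No size of step can be read from them, so the expectation for compound 4 is that it again sits at the limit, with a step that the limit leaves unreadable from compound 3 to compound 4 expected as no change beyond the scatter. Compound 4 is therefore estimated at 30000 nM, between 12000 nM and 100000 nM.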

Compound 4, half-maximal cytotoxic concentration: > 20000 nM
Compound 4 ended at the assay's limit (the forecaster's own chance of this, stated with the estimate: 80%); the middle value does not contradict the limit.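

In this assay, for the compounds shown here, compound 4 gives only a limit, > 20000 nM, so no step between it and compound 1, compound 2 or compound 3 can be read. The compounds shown leave open at what concentration any of them becomes toxic to these cells.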